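The compounds below may be only part of what the source reports. "The series", "measured", "known", "first", "only" and "open" are said of these compounds alone.

In an in vivo ADME assay on the whole organism for pharmacokinetics, with Rattus norvegicus as the target, at a dose of 1 mg/kg by the intravenous route (on this read-out lower numbers stand for slow clearance and higher numbers for fast clearance), compound 1 `CN(C)CC(=O)NCc1c(CN(C)[C@H]2CCCc3cccnc32)ncc2ccccc12` gives 11 mL/min/kg, and compound 2 `CN(C)C(=O)NCCCc1c(CN(C)[C@H]2CCCc3cccnc32)ncc2ccccc12` gives 16 mL/min/kg. Among the compounds with values here, these are the only two measurements so far, and they lie within the scatter of each other, so compound 2 stands level with compound 1 on this read-out. The next structure, compound 3 `CN(Cc1ncc2ccccc2c1CCCNS(C)(=O)=O)[C@H]1CCCc2cccnc21`, keeps the shared core and the chain of compound 2 but carries methylsulfonyl in place of dimethylcarbamoyl on an amine nitrogen. The same difference can be read as (dimethylcarbamoyl)amino to methanesulfonamido. Within the data shown here, no measured pair makes this exchange, so the data hold no direct measure of it. Among the measured compounds shown here, only one measured step bears on it, and only loosely: a 1.5-fold higher number from compound 1 to compound 2 (0.16 log units; within the scatter), a rebuilding of the same side chain that stayed within the scatter. On that single precedent, no shift beyond the scatter is expected in this assay, and no direction can be favoured. The expected step is a 1.1-fold lower number from compound 2 to compound 3 (0.03 log units; within the scatter). For compound 3 the estimated value is 15 mL/min/kg, with an expected range from 7 mL/min/kg to 32 mL/min/kg.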

Compound 3, clearance: 9.5 mL/min/kg
For compound 3 the middle estimate is 1.6-fold (0.20 log units) above the measured one; measured number inside the range.
By their numbers in this assay, from the lowest: compounds 3, 1 and 2 (each within the scatter of the next).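

In this assay, the exchange of dimethylcarbamoyl for methylsulfonyl on the amine nitrogen now has a direct measure, a 1.7-fold lower number from compound 2 to compound 3 (0.23 log units; within the scatter) on the same chain, so at this position neither group stands apart from the other. The comparison with the other side chain gives a 1.2-fold lower number from compound 1 to compound 3 (0.06 log units; within the scatter) and so adds a third form of the side chain that lies within the scatter of compound 1, which means that a urea, a sulfonamide and an amide carrying a dimethylamino group have so far given no step beyond the scatter in this assay. Nothing at hand speaks to what lies behind these numbers.

The three compounds therefore mark no limit for this position, and they leave open whether any side chain can move clearance beyond the scatter at all. On these data alone, a carboxylic acid at the end of the chain, a primary amine in that place, or a longer chain carrying the methanesulfonamido group could each answer that, and the shared core itself remains untested by these compounds.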